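A few compounds are considered here, and "the series" means these few. Any claim that something is new, unique, unknown or untested is made for them only; others in the source may bear on it.

Compound 1 `N#CC1=C(N)N(c2ccc(S(N)(=O)=O)cc2)C2=C(CCCC2)C1c1ccccc1` and compound 2 `N#CC1=C(N)N(c2ccc(S(N)(=O)=O)cc2)C2=C(CCCC2)C1c1ccc([N+](=O)[O-])cc1` share one core. In a functional assay on Ehrlich cells (Mus musculus) for cytotoxicity, read by trypan blue exclusion, with a stated time of 2 h, tested at 10 ug/mL (on this read-out lower numbers stand for a weaker effect and higher numbers for a stronger effect at the one concentration tested), compound 1 gives 5%, and in the same test compound 2 gives 0%. The step of a number 5 percentage points lower from compound 1 to compound 2 (within the scatter) lies within the scatter. On the numbers shown compound 2 sits at the lowest of the two, with compound 1 a step away that is within the scatter. Compound 3 `N#CC1=C(N)N(c2ccc(S(N)(=O)=O)cc2)C2=C(CCCC2)C1c1c(O)ccc2ccccc12` differs from compound 2 by 2-hydroxynaphthalen-1-yl in place of 4-nitrophenyl on a saturated ring carbon. Within the data shown here, no measured step exchanges this group, so in this assay nothing beyond the scatter is expected. Compound 3 is estimated at 5%, ranging from 0% to 20%. The expected step is a number 5 percentage points higher from compound 2 to compound 3 (within the scatter).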

Compound 3, a percentage reported as activity, at one concentration (the size of the read-out at that concentration, not a potency): 10%
Compound 3: middle estimate off by 5 percentage points, on the low side; the range from low to high includes it.
By their numbers in this assay, from the lowest: compounds 2, 1 and 3 (each within the scatter of the next).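

The steps of a number 10 percentage points higher from compound 2 to compound 3 (within the scatter) and a number 5 percentage points higher from compound 1 to compound 3 (within the scatter) show that in this assay 2-hydroxynaphthalen-1-yl, with its two aromatic rings and its hydrogen-bond donor, stays within the scatter of both 4-nitrophenyl and phenyl on this saturated ring carbon. The three aromatic groups at this position therefore cannot be told apart at the one concentration tested. Nothing available explains this result. From the compounds shown here alone, whether any group on this carbon gives a number beyond the scatter stays open, for instance a carboxylic acid or a morpholine in place of the aromatic ring. Also open, going by these compounds, is how the shared core reads with a benzyl group in place of 4-sulfamoylphenyl.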